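A few compounds are considered here, and "the series" means these few. Any claim that something is new, unique, unknown or untested is made for them only; others in the source may bear on it.

Measured so far in a functional assay on Bel7402/5-FU cells (Homo sapiens) for antiproliferative activity, read by MTT assay, with a stated time of 72 h; on this read-out higher numbers stand for weaker inhibition and lower numbers for stronger inhibition:

compound 1, `C=C1C(=O)O[C@H]2[C@H]1CC/C(COC(=O)CCC(=O)NCCCCCCNC(=O)Cn1cc(F)c(=O)n(Cc3ccccc3)c1=O)=C\CC[C@@]1(C)O[C@@H]21`: 16200 nM
compound 2, `C=C1C(=O)O[C@H]2[C@H]1CC/C(COC(=O)CCC(=O)N1CCN(C(=O)Cn3cc(F)c(=O)n(Cc4ccccc4)c3=O)CC1)=C\CC[C@@]1(C)O[C@@H]21`: for compound 2 the read-out is a limit, > 20000 nM, which is the limit of > 20000 nM in this assay, at which 1 of the 3 values shown sits.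
compound 3, `C=C1C(=O)O[C@H]2[C@H]1CC/C(COC(=O)Cn1cc(F)c(=O)n(Cc3ccc(C(F)(F)F)cc3)c1=O)=C\CC[C@@]1(C)O[C@@H]21`: 2250 nM

Of the two numbers shown, compound 3 stands lowest; the nearest number, that of compound 1, sits beyond the scatter above it, and the remaining entry for compound 2 is a limit rather than a number. Going by the values given here, no pair of measured compounds differs in a single place, so no measured step is available to lean on, and the three measured compounds differ in both the linker and the group on the aromatic nitrogen.

Compound 4 is `C=C1C(=O)O[C@H]2[C@H]1CC/C(COC(=O)Cn1cc(F)c(=O)n(CCC)c1=O)=C\CC[C@@]1(C)O[C@@H]21`. It keeps the linker of compound 3 and differs only in ethyl in place of 4-(trifluoromethyl)phenyl on a saturated chain carbon bound to an aromatic nitrogen. With no measured step of this kind in the set, the expectation for this assay rests on compound 3 alone, and a small loss in inhibition is expected with this change, of a size that may not clear the scatter. The step from compound 3 to compound 4 is estimated as a 2.0-fold higher number from compound 3 to compound 4 (0.30 log units; within the scatter). Compound 4 is expected to give 4500 nM, within 1500 nM to 14000 nM.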

Compound 4, half-maximal inhibitory concentration: 9110 nM
Compound 4: the middle estimate sits 2.0-fold (0.31 log units) below what was measured; low and high end bracket the measured number.
By their numbers in this assay, from the lowest: compound 3; then compounds 4 and 1 (each within the scatter of the next). At a limit, above all of these: compound 2.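

In this assay, going by these compounds alone, putting ethyl in place of 4-(trifluoromethyl)phenyl on a saturated chain carbon bound to an aromatic nitrogen gives a 4.0-fold higher number from compound 3 to compound 4 (0.61 log units; beyond the scatter) and provides the first reading of a change in one place, showing that this group affects the read-out with the linker of compound 3 held constant. The change removes a six-membered aromatic ring and reduces the group from 10 heavy atoms to 2, while neither group carries a hydrogen-bond donor, a hydrogen-bond acceptor or a net charge, so the step is not tied to a change in any of those three counts. No measurement shown bears on why the number rises with this change.

This single pair cannot separate the loss of the ring from the loss of the trifluoromethyl group or from the smaller size of the group, and unsubstituted phenyl, 4-fluorophenyl or a longer unbranched alkyl chain at this place would begin to tell these apart. It also leaves open how a terminal amine or a carboxylic acid on that chain would read out, and whether the step holds with the linkers of compound 1 and compound 2.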